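A few compounds are considered here, and "the series" means these few. Any claim that something is new, unique, unknown or untested is made for them only; others in the source may bear on it.

Measured in a functional assay on A549 cells (Homo sapiens) for antiproliferative activity, read by MTT assay, with a stated time of 24 h; on this read-out higher numbers stand for weaker inhibition and lower numbers for stronger inhibition:
- compound 1 `Cc1ccc(-c2nn(-c3ccccc3)cc2-c2nc3ccccc3n2S(=O)(=O)c2ccc(C)cc2)cc1` gives 460 nM
- compound 2 `Cc1ccc(-c2nn(-c3ccccc3)cc2-c2nc3ccccc3n2S(=O)(=O)c2cc(C)ccc2C)cc1` gives 270 nM
- compound 3 `Cc1ccc(-c2nn(-c3ccccc3)cc2-c2nc3ccccc3n2S(=O)(=O)c2ccc(F)cc2)cc1` gives 3240 nM

Compound 3 has the highest number of the three, with a 7.0-fold higher number from compound 1 to compound 3 (0.85 log units; beyond the scatter) and a 12-fold higher number from compound 2 to compound 3 (1.08 log units; beyond the scatter) as the steps that set it apart. Compound 4 `O=S(=O)(c1ccc(F)cc1)n1c(-c2cn(-c3ccccc3)nc2-c2ccc(C(F)(F)F)cc2)nc2ccccc21` carries trifluoromethyl in place of methyl on an aromatic carbon, para to a large group. Among the compounds with values here, no measured step touches this group, since a 1.7-fold lower number from compound 1 to compound 2 (0.23 log units; within the scatter) and the two steps above all concern the group on the sulfonyl sulfur. They show only that the series can move. No step beyond the scatter is therefore expected in this assay and the estimate is a 1.1-fold lower number from compound 3 to compound 4 (0.03 log units; within the scatter) as the expected change. Compound 4 is expected at 3000 nM with an estimated range from 700 nM to 12000 nM as its span.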

Compound 4, half-maximal inhibitory concentration: 1740 nM
Beside the measured number, compound 4's estimate is 1.7-fold (0.24 log units) above it, within the range that was stated.
By their numbers in this assay, from the lowest: compounds 2 and 1 (each within the scatter of the next); then compounds 4 and 3 (each within the scatter of the next).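

In this assay, within the data shown here, the swap of methyl for trifluoromethyl gives the first reading at this position, para to a large group, and a 1.9-fold lower number from compound 3 to compound 4 (0.27 log units; within the scatter) shows no separation between the two compounds. Among these compounds, with 4-fluorophenyl kept on the sulfonyl sulfur, the 4-(trifluoromethyl)phenyl group therefore serves as well as 4-methylphenyl, whereas the earlier steps concerned only the sulfonyl group. No measurement offered here explains this result. The compounds shown leave open whether the same swap reads alike with 2,5-dimethylphenyl on the sulfonyl sulfur. They also leave open how an amine or a carboxylic acid would fare at this position.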